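The source may report more compounds than this note shows. Statements on the series, on what has been measured and on what is new or still open speak of the compounds shown alone.

Compound 1 `CCCCCCCCCCCC(=O)OC[C@H](CSC[C@@H](N)C(=O)NCCCS(=O)(=O)O)OC(=O)CCCCCCCCCCC` and compound 2 `CCCCCCCCCCCC(=O)OC[C@H](CSC[C@@H](N)C(=O)N[C@@H](CC)COCC(=O)O)OC(=O)CCCCCCCCCCC` share a core and differ only in the group on an amide-type nitrogen. In an assay on HEK293 cells for agonist activity at Toll-like receptor 2 (Homo sapiens) (a lower number here means that less compound is needed, a higher number that more compound is needed for the effect), compound 1 gives 5560 nM and compound 2 gives 6500 nM. The change between them is a 1.2-fold higher number from compound 1 to compound 2 (0.07 log units; within the scatter), so the two values sit together within the scatter, and compound 2 has the higher of the two numbers only nominally; no order can be read from them.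

Compound 3 `CCCCCCCCCCCC(=O)OC[C@H](CSC[C@@H](N)C(=O)NCCCCCCCCCC(=O)O)OC(=O)CCCCCCCCCCC` carries the next change at the same amide-type nitrogen: 9-carboxynonyl in place of 1-((carboxymethoxy)methyl)propyl on an amide-type nitrogen. Among the compounds with values here, the one measured step that bears on this position is the one from compound 1 to compound 2, which stayed within the scatter, so a change of the group on this nitrogen has so far left this assay unmoved. Compound 3 is therefore expected to show no step beyond the scatter, that is a 1.1-fold lower number from compound 2 to compound 3 (0.03 log units; within the scatter). On that basis compound 3 is estimated at 6000 nM in this assay, with a plausible range from 2500 nM to 14000 nM.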

Compound 3, half-maximal effective concentration: 4400 nM
Compound 3: the middle estimate sits 1.4-fold (0.13 log units) above what was measured, and the stated range covers the measured number.
By their numbers in this assay, from the lowest: compounds 3, 1 and 2 (each within the scatter of the next).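

Putting 9-carboxynonyl, with 12 heavy atoms and no defined stereocentre, in place of 1-((carboxymethoxy)methyl)propyl, with 9 heavy atoms and 1 defined stereocentre, gives a 1.5-fold lower number from compound 2 to compound 3 (0.17 log units; within the scatter) in this assay, so neither the added heavy atoms nor the loss of that stereocentre carries this number beyond the scatter. The comparison with the sulfonic acid end of compound 1 reads the same way: 6-carboxyhexyl in place of sulfo on a saturated chain carbon, three bonds along the chain from an amide-type nitrogen, gives a 1.3-fold lower number from compound 1 to compound 3 (0.10 log units; within the scatter), and so all three groups on this nitrogen now sit together in this assay, whether the chain ends in a sulfonic acid or a carboxylic acid. No supporting evidence is available to explain this result.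

All three groups shown end in an acid, so it remains open whether the number in this assay would hold with an amine, a hydroxyl or a plain methyl at the chain end. As far as these compounds go, it also remains open whether a much shorter chain such as ethyl, or a phenyl ring on this nitrogen, would move the number beyond the scatter.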